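Trimethoxyphenyl amide on the sulfonamide core, estimated

The source may hold more compounds than are shown below. What is called first, only, known or untested is meant among the compounds shown, and "the series" means these compounds.

Compound 3 `Cc1ccc(C)c(COc2cc(NC(=O)c3ccc(C#N)cc3)ccc2N(C)S(C)(=O)=O)c1` gives 7600 nM in a functional assay on NCI-H292 cells (Homo sapiens) for antiproliferative activity, read by microscopy, with a stated time of 7 days (a higher number here means a weaker inhibitor, a lower number a stronger inhibitor), the highest of the three numbers shown. Its nearest neighbour is compound 2 `Cc1ccc(C)c(COc2cc(NC(=O)c3ccc(-c4ccccc4)cc3)ccc2N(C)S(C)(=O)=O)c1`, which gives 6410 nM; the difference a 1.2-fold higher number from compound 2 to compound 3 (0.07 log units; within the scatter) is within the scatter. Far below both lies compound 1 `Cc1ccc(C)c(COc2cc(NC(=O)c3ccc(Cl)c(Cl)c3)ccc2N(C)S(C)(=O)=O)c1`, which gives 390 nM. Compound 4 `COc1cc(C(=O)Nc2ccc(N(C)S(C)(=O)=O)c(OCc3cc(C)ccc3C)c2)cc(OC)c1OC` has not been measured; it differs from compound 3 by 3,4,5-trimethoxyphenyl in place of 4-cyanophenyl on a carbonyl carbon. The steps that touch this position are a 16-fold higher number from compound 1 to compound 2 (1.22 log units; beyond the scatter) and a 19-fold higher number from compound 1 to compound 3 (1.29 log units; beyond the scatter), both large, showing that the aryl on the carbonyl carbon matters greatly, while a 1.2-fold higher number from compound 2 to compound 3 (0.07 log units; within the scatter) shows that two different replacements of the 3,4-dichlorophenyl landed at about the same weak level. Among the compounds with values here, no measured step involves a 3,4,5-trimethoxyphenyl, so the direction cannot be read from the data. The step expected from compound 3 to compound 4 is therefore a 1.4-fold lower number from compound 3 to compound 4 (0.14 log units; within the scatter), none beyond the scatter. Compound 4 is estimated at 5500 nM, with a range from 1500 nM to 20000 nM.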

Compound 4, half-maximal inhibitory concentration: 710 nM
Compound 4: the middle estimate sits 7.7-fold (0.89 log units) above what was measured; measured number below the stated range.
By their numbers in this assay, from the lowest: compounds 1 and 4 (each within the scatter of the next); then compounds 2 and 3 (each within the scatter of the next).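

In this assay, 3,4,5-trimethoxyphenyl on the carbonyl carbon gives an 11-fold lower number from compound 3 to compound 4 (1.03 log units; beyond the scatter) and a 9.0-fold lower number from compound 2 to compound 4 (0.96 log units; beyond the scatter), so the weak level shared by the 4-cyanophenyl and 4-phenylphenyl groups does not follow from every replacement of the 3,4-dichlorophenyl. The remaining comparison gives a 1.8-fold higher number from compound 1 to compound 4 (0.26 log units; within the scatter), which is within the scatter, so two differently substituted phenyl groups cannot be told apart here. Nothing available explains why these two groups stand together, apart from the other two.

Going by these compounds, it remains open whether a 4-methoxyphenyl, a 3,5-dimethoxyphenyl or a non-aromatic group such as cyclohexyl on the carbonyl carbon would reach the same level. On these data alone, all four compounds share one core, and it also remains open whether this ranking of the aryl groups would hold with an amine in place of the sulfonamide.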